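The compounds below may be only part of what the source reports. "The series", "measured", "known", "first", "only" and "open" are said of these compounds alone.

Measured compounds in an assay on cell membranes (strain Wistar) for inhibition of Fatty-acid amide hydrolase 1 (Rattus norvegicus), read by scintillation counting; a higher number here means a weaker inhibitor, a lower number a stronger inhibitor:
- compound 1, `O=C(NC1CCCC1)Oc1ccc(C2=NCCO2)cc1`: compound 1 gives 100 nM
- compound 2, `CCCCCCNC(=O)Oc1ccc(-c2csnn2)cc1`: compound 2 gives 19 nM

Compound 2 holds the lowest number of the two; compound 1 sits well above it, beyond the scatter, but the two differ in more than one place, so no single step can be read from them. Compound 3, `O=C(NC1CCCCC1)Oc1ccc(-c2csnn2)cc1`, differs from compound 2 by cyclohexyl in place of hexyl on an amide-type nitrogen. Among the measured compounds shown here, no measured pair bears on that change; the expected step of a 1.1-fold higher number from compound 2 to compound 3 (0.02 log units; within the scatter) is none beyond the scatter, in either direction. Compound 3 is therefore expected at 20 nM, with a range of 5 nM to 80 nM.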

Compound 3, half-maximal inhibitory concentration: 21 nM
For compound 3 the middle estimate is 1.1-fold (0.02 log units) below the measured one, within the range that was stated.
By their numbers in this assay, from the lowest: compounds 2 and 3 (each within the scatter of the next); then compound 1.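

In this assay, among the compounds shown here, cyclohexyl in place of hexyl on an amide-type nitrogen gives a 1.1-fold higher number from compound 2 to compound 3 (0.04 log units; within the scatter), the first comparison that isolates a single place. At this position, the ring and the open chain are therefore not told apart by this read-out. Nothing on hand offers an explanation for this result.

On these data alone, whether a shorter chain such as butyl, or a benzyl group, would be tolerated equally on this nitrogen remains open. As far as these compounds go, compound 1 differs from compound 3 in more than one place, so the effect of cyclopentyl on the core of compound 3 also remains open.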